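Two Weak Growth Inhibitors and an Untested Dimethoxy Analogue

The source may report more compounds than this note shows. Statements on the series, on what has been measured and on what is new or still open speak of the compounds shown alone.

Compound 1 `Nc1cc(N)c2nc(-c3ccccc3)c(NCc3ccc(Cl)c(Cl)c3)nc2c1`: 17000 nM
Compound 2 `Nc1cc(N)c2nc(-c3ccccc3)c(Oc3ccc(F)cc3)nc2c1`: 20000 nM

Both measured compounds were examined in a functional assay on COLO 205 cells (Homo sapiens) for inhibition, read by sulforhodamine B assay, with a stated time of 48 h; on this read-out higher numbers stand for weaker inhibition of growth and lower numbers for stronger inhibition of growth. Compound 1 gives 17000 nM there, and compound 2 gives 20000 nM. Compound 1 has the lower of the two numbers, but its gap to compound 2 lies within the scatter, so the two cannot be told apart on these data, and neither can be called the stronger inhibitor.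

Compound 3 `COc1ccc(CNc2nc3cc(N)cc(N)c3nc2-c2ccccc2)cc1OC` has not yet been measured. It differs from compound 1 by 3,4-dimethoxyphenyl in place of 3,4-dichlorophenyl on a saturated chain carbon bound to a nitrogen on an aromatic ring. Going by the values given here, no measured pair shows how such a change acts in this assay, and the two known values sit close together at weak inhibition of growth. With nothing pointing in either direction, the step of a 1.2-fold higher number from compound 1 to compound 3 (0.07 log units; within the scatter) is expected to stay within the scatter, though the range is left wide to allow for movement either way. Compound 3 is estimated at 20000 nM in this assay, with a range from 7000 nM to 60000 nM.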

Compound 3, concentration for 50% growth inhibition: 7940 nM
Estimate against measurement, compound 3: 2.5-fold (0.40 log units) above; measured number inside the range.
By their numbers in this assay, from the lowest: compound 3; then compounds 1 and 2 (each within the scatter of the next).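

Going by these compounds alone, replacing 3,4-dichlorophenyl with 3,4-dimethoxyphenyl on a saturated chain carbon bound to a nitrogen on an aromatic ring gives the only readable step so far in this assay: a 2.1-fold lower number from compound 1 to compound 3 (0.33 log units; beyond the scatter), a modest change towards stronger inhibition of growth that lies beyond the scatter. This shows that, with the rest of compound 1 held constant, the number responds to what the aryl group carries at this position, although compound 3, at 7940 nM, moves only a short way from its parent. The entering group brings 2 hydrogen-bond acceptors where the leaving group has 0, but nothing at hand explains why the number moves, and no supporting measurement bears on the step.

This single pair cannot separate the effect of adding the two methoxy groups from that of losing the two chlorine atoms, and an unsubstituted phenyl or a group with a single methoxy would be needed to tell them apart. Nor do the compounds shown say how a more different group at this position, such as a morpholine or a carboxylic acid, would read in this assay.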